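The source may report more compounds than this note shows. Statements on the series, on what has been measured and on what is new or still open speak of the compounds shown alone.

Measured so far in a functional assay on the whole organism (plasma, strain Sprague-Dawley) with Rattus norvegicus as the target, with a stated time of 2 h, at a dose of 25 mg/kg by the oral route; on this read-out lower numbers stand for a weaker effect and higher numbers for a stronger effect at the one dose given:

Compound 1 `c1ccc(C(/N=C2\CCCCN2)C2CC2)cc1` gives 23%.
Compound 2 `c1ccc(C(/N=C2\CCCCCN2)C2CC2)cc1` gives 18%.
Compound 3 `Cc1ccc(C(/N=C2\CCCCCCCN2)C2CC2)c(C)c1` gives 37%.

Compound 2 has the lowest of the three numbers in this assay. Compound 1 sits within the scatter of it, so the two cannot be told apart. Compound 3 sits beyond the scatter, on the higher side; it differs from compound 2 in more than one place, so nothing follows from it for any single change.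

Compound 4 `c1ccc(C(/N=C2\CCCCCN2)c2ccco2)cc1` has not been measured. It differs from compound 2 in one place: furan-2-yl in place of cyclopropyl on a saturated chain carbon bound to an aromatic carbon and a double-bonded nitrogen. Going by the values given here, no measured pair carries this change, and no two measured compounds differ in a single place at all, so there is no step to lean on. In this assay a step of no size beyond the scatter is expected, with no direction to favour. For compound 4 a value of 22% is estimated, in the range 5% to 45%. The expected step is then a number 4 percentage points higher from compound 2 to compound 4 (within the scatter).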

Compound 4, a percentage reported as inhibition, in the whole organism at one dose (the size of the read-out at that dose, not a potency): 34%
Compound 4: middle estimate off by 12 percentage points, on the low side, within the range that was stated.
By their numbers in this assay, from the lowest: compounds 2 and 1 (each within the scatter of the next); then compounds 4 and 3 (each within the scatter of the next).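

In this assay, going by these compounds alone, furan-2-yl in place of cyclopropyl gives a number 16 percentage points higher from compound 2 to compound 4 (beyond the scatter), the only single-place step so far. Within the data shown here, this shows that the group on a saturated chain carbon bound to an aromatic carbon and a double-bonded nitrogen can shift this read-out at the one dose given, which the earlier compounds, differing in more than one place, could not show. No available data bear on the reason for this step.

Open, from the compounds shown here alone, is whether the step goes with the aromatic ring, the ring oxygen or the larger group, a question that phenyl, thiophen-2-yl or an isopropyl group at this place could help separate. Also open, going by these compounds, is whether the same change gives a similar step on the core of compound 1 or compound 3.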